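The source may hold more compounds than are shown below. What is called first, only, known or untested is meant among the compounds shown, and "the series" means these compounds.

Of the compounds shown here, two have so far been tested in a functional assay on MDA-MB-231 cells (Homo sapiens) for antiproliferative activity, read by MTT assay, with a stated time of 72 h; on this read-out lower numbers stand for stronger inhibition and higher numbers for weaker inhibition. For the measured compounds named here, compound 1 `O=C(Nc1cccc(-c2nc(-c3ccc(NC(=O)c4cccnc4)cc3Cl)no2)c1)c1ccccc1` gives 12800 nM in this assay, and that is the only plain number available. Compound 2 `O=C(Nc1ccc(-c2noc(-c3cccc(NS(=O)(=O)c4ccc(NC(=O)N5CCOCC5)cc4)c3)n2)c(Cl)c1)c1cccnc1` gives > 10000 nM in this assay, which is a limit of the assay rather than a number. Going by the values given here, because the limit of > 10000 nM in this assay, at which 1 of the 2 values shown sits, is the only other reading, compound 1 stands as the single compound with a measured value, and that value points to weak inhibition.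

Compound 3 `CC(=O)Nc1ccc(NC(=O)Nc2cccc(-c3nc(-c4ccc(NC(=O)c5cccnc5)cc4Cl)no3)c2)cc1` is the next compound to be measured in this assay. It differs from compound 1 in one place: (4-acetamidophenyl)amino in place of phenyl on a carbonyl carbon. Among the compounds with values here, no pair of measured compounds differs in a single place, so there is no measured step from which the size of this change can be read off. The expected change a 1.4-fold lower number from compound 1 to compound 3 (0.15 log units; within the scatter) is small, not beyond the usual scatter, with no clear direction, since the starting value of compound 1 at 12800 nM is already weak. Compound 3 is therefore estimated at 9000 nM, with a range from 2000 nM to 40000 nM.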

Compound 3, half-maximal inhibitory concentration: > 10000 nM
Compound 3 ended at the assay's limit (the forecaster's own chance of this, stated with the estimate: 40%); middle value at least 1.1-fold (0.04 log units) from the limit.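

In this assay compound 3 gives > 10000 nM and this is a limit of the assay, not a number. For the compounds shown here, no step can therefore be read between compound 1 and compound 3: the limit of > 10000 nM in this assay, at which 2 of the 3 values shown sit.

The compounds shown leave open whether (4-acetamidophenyl)amino in place of phenyl on the carbonyl carbon changes the inhibition at all.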